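Moving the Chlorine Around the Aryl Ring

A few compounds are considered here, and "the series" means these few. Any claim that something is new, unique, unknown or untested is made for them only; others in the source may bear on it.

Compound 2 `Clc1cccc(-c2nc3ccc(N4CCCCC4)nc3o2)c1` and compound 1 `Fc1ccccc1-c1nc2ccc(N3CCCCC3)nc2o1` share one core and differ only in the aryl group. In an assay on isolated protein for inhibition of Amine oxidase [flavin-containing] B (Homo sapiens), read by fluorescence, with a stated time of 1 h, tested at 10 uM (a higher number here means more inhibition at the concentration tested (going by the name of the read-out), a lower number less inhibition), compound 1 gives 94.9% and compound 2 gives 91.7%; the step of a number 3.2 percentage points lower from compound 1 to compound 2 (within the scatter) lies within the scatter, and compound 2 holds the lower of the two numbers, its nearest neighbour being compound 1. Compound 3 `Clc1ccc(-c2nc3ccc(N4CCCCC4)nc3o2)cc1` is not yet measured and differs from compound 2 by 4-chlorophenyl in place of 3-chlorophenyl on an aromatic carbon. Going by the values given here, the only measured step, also a change of the aryl group, stayed within the scatter, so the expected step is a number 1.7 percentage points lower from compound 2 to compound 3 (within the scatter), nothing beyond the scatter. Compound 3 is estimated at 90%, ranging from 75% to 98%.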

Compound 3, a percentage reported as inhibition, at one concentration (the size of the read-out at that concentration, not a potency): 69.8%
Compound 3: the middle estimate sits 20.2 percentage points above what was measured; the measured number lies below the stated range.
By their numbers in this assay, from the lowest: compound 3; then compounds 2 and 1 (each within the scatter of the next).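

In this assay the aryl group at this position is not indifferent to where its chlorine sits: 4-chlorophenyl in place of 3-chlorophenyl gives a number 21.9 percentage points lower from compound 2 to compound 3 (beyond the scatter), a step beyond the scatter with the same atoms joined differently, which the earlier step between compound 1 and compound 2 did not reveal. Against 2-fluorophenyl the change gives a number 25.1 percentage points lower from compound 1 to compound 3 (beyond the scatter) as well. Nothing available explains why the number falls with 4-chlorophenyl. As far as these compounds go, whether 2-chlorophenyl would stand with compound 1 and compound 2 stays open, as does whether 4-methoxyphenyl or 4-aminophenyl would fall with compound 3.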